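The source may hold more compounds than are shown below. What is called first, only, known or untested is meant among the compounds shown, and "the series" means these compounds.

Compound 1 `CC1(C)C=C(n2ccccc2=O)c2cc(S(N)(=O)=O)ccc2O1` gives 69.2 nM in a functional assay with Rattus norvegicus as the target (on this read-out higher numbers stand for an effect only at larger amounts of compound and lower numbers for an effect already at smaller amounts), the second highest of the three numbers in hand. Compound 2 `CNS(=O)(=O)c1ccc2c(c1)C(n1ccccc1=O)=CC(C)(C)O2` gives 17.8 nM, and compound 3 `CC(C)NS(=O)(=O)c1ccc2c(c1)C(n1ccccc1=O)=CC(C)(C)O2` gives 676 nM. The change to compound 4 `CC1(C)C=C(n2ccccc2=O)c2cc(S(=O)(=O)NCc3ccccc3)ccc2O1` is benzyl in place of hydrogen on a sulfonamide nitrogen. Both measured steps that bear on it start from the same sulfonamide hydrogen: methyl gave a 3.9-fold lower number from compound 1 to compound 2 (0.59 log units; beyond the scatter), whereas isopropyl gave a 9.8-fold higher number from compound 1 to compound 3 (0.99 log units; beyond the scatter), and between those two groups the step was a 38-fold higher number from compound 2 to compound 3 (1.58 log units; beyond the scatter). Of the two substituents tried on this nitrogen, the one with more carbon atoms gave the higher number, so for compound 4 a step in the direction of compound 3 is expected, about a 5.8-fold higher number from compound 1 to compound 4 (0.76 log units; beyond the scatter). Compound 4 is accordingly estimated at 400 nM, within 100 nM to 1600 nM.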

Compound 4, half-maximal effective concentration: 525 nM
For compound 4 the middle estimate is 1.3-fold (0.12 log units) below the measured one; measured number inside the range.
By their numbers in this assay, from the lowest: compound 2; then compound 1; then compounds 4 and 3 (each within the scatter of the next).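

Benzyl on the sulfonamide nitrogen gives a 7.6-fold higher number from compound 1 to compound 4 (0.88 log units; beyond the scatter), the same direction as isopropyl, while a 1.3-fold lower number from compound 3 to compound 4 (0.11 log units; within the scatter) leaves those two groups unseparated, so the rise does not continue from isopropyl to benzyl. Methyl remains the only substituent here that goes against this direction, and adding phenyl to its saturated chain carbon gives a 29-fold higher number from compound 2 to compound 4 (1.47 log units; beyond the scatter). Nothing available accounts for these steps.

From the compounds shown here alone, whether the lower number is confined to methyl or extends to ethyl remains open. So does the outcome with an amine or a carboxylic acid on a longer chain at this nitrogen.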